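A few compounds are considered here, and "the series" means these few. Any claim that something is new, unique, unknown or untested is made for them only; others in the source may bear on it.

Working notes on the series, read in an ADME assay on the whole organism (Rattus norvegicus) for pharmacokinetics, at a dose of 1 mg/kg by the intravenous route; on this read-out lower numbers stand for lower exposure and higher numbers for higher exposure at the dose given:

- compound 1 `O=C(c1cnco1)N1CCC(C(=O)N2N=CC[C@H]2c2ccccc2)CC1`: 400 ng.h/mL
- compound 2 `Cc1nnc(N2CCC(C(=O)N3N=CC[C@H]3c3ccccc3)CC2)o1`: 800 ng.h/mL
- compound 3 `O=C(c1cn[nH]c1)N1CCC(C(=O)N2N=CCC2c2ccccc2)CC1`: 360 ng.h/mL

Compound 2 (800 ng.h/mL) lies within the scatter of compound 1 (400 ng.h/mL). Its number is higher than that of compound 3 (360 ng.h/mL), a gap beyond the scatter.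

The next compound is compound 4 `CC(=O)N1CCC(C(=O)N2N=CC[C@H]2c2ccccc2)CC1`, with acetyl in place of 5-methyl-1,3,4-oxadiazol-2-yl on an amine nitrogen in a ring. For the measured compounds named here, no measured compound carries acetyl at this place, so the evidence is indirect.

Going by the values given here, the one measured step at this place is a 2.0-fold higher number from compound 1 to compound 2 (0.30 log units; within the scatter). It brings in the same 5-methyl-1,3,4-oxadiazol-2-yl group that compound 4 gives up, and it stays within the scatter. Compound 4 has a carbonyl on that nitrogen, as do compound 1 (400 ng.h/mL) and compound 3 (360 ng.h/mL). A small move to a lower number in this assay is therefore expected, with no step beyond the scatter. The expected change is a 1.6-fold lower number from compound 2 to compound 4 (0.20 log units; within the scatter).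

For compound 4 the estimated value is 500 ng.h/mL, with an expected range of 220 ng.h/mL to 1100 ng.h/mL.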

Compound 4, area under the concentration-time curve: 420 ng.h/mL
Beside the measured number, compound 4's estimate is 1.2-fold (0.08 log units) above it; the range from low to high includes it.
By their numbers in this assay, from the lowest: compounds 3, 1, 4 and 2 (each within the scatter of the next, the first and the last beyond it).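

With this assay as the read-out, acetyl in place of 5-methyl-1,3,4-oxadiazol-2-yl on an amine nitrogen in a ring gives a 1.9-fold lower number from compound 2 to compound 4 (0.28 log units; within the scatter) and thus shows that a group with no ring and 3 heavy atoms can take the place of one with a five-membered aromatic ring and 6 heavy atoms without a step beyond the scatter. Methyl in place of 1,3-oxazol-5-yl on a carbonyl carbon gives a 1.1-fold higher number from compound 1 to compound 4 (0.02 log units; within the scatter) and shows the same for the aromatic ring on that carbonyl, whereas the earlier compounds offered only one step at this place, between two ring-bearing groups. Ring-bearing and ring-free groups at this place are therefore not separated on this read-out, and no measured property of these groups is available to account for the numbers.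

The compounds shown leave open whether a longer acyl chain, a sulfonyl group or a carboxylic acid on this nitrogen would give a step beyond the scatter in this assay and so mark a limit to what this place tolerates. They also leave open whether changes elsewhere on the shared core would move the number further than any change at this place has so far.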